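The source may report more compounds than this note shows. Statements on the series, on what has been measured and on what is new or still open speak of the compounds shown alone.

Working notes on the series. Compound 1 `CC(O)(CS(=O)(=O)c1ccc(Br)cc1)c1nc(-c2ccc([N+](=O)[O-])c(C(F)(F)F)c2)no1` and compound 2 `CC(O)(CS(=O)(=O)c1ccc(F)cc1)c1nc(-c2ccc(F)c(Cl)c2)no1` share the same core. In a functional assay on DU-145 cells (Homo sapiens) for cytotoxicity, read by MTT assay (a higher number here means a weaker inhibitor, a lower number a stronger inhibitor), compound 1 gives only a limit of the assay, > 100000 nM. In this assay compound 2 likewise gives only a limit, > 100000 nM. Compound 2 thus stands at the limit of > 100000 nM in this assay, at which 2 of the 2 values shown sit. Compound 3 `CC(O)(CS(=O)(=O)c1ccccc1)c1nc(-c2ccc(F)c(Cl)c2)no1` differs from compound 2 by hydrogen in place of fluoro on an aromatic carbon. Going by the values given here, no step between measured compounds is known. The expected step in this assay is a number no higher from compound 2 to compound 3 (the limit leaves the size open), none beyond the scatter. Compound 3 is therefore estimated at 100000 nM, within 40000 nM to 250000 nM, most likely reported again only as a limit.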

Compound 3, half-maximal inhibitory concentration: > 100000 nM
Compound 3: no number, only a limit; the forecaster's own chance of this, stated with the estimate: 80%; the middle value sits exactly at the limit.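

No step can be read between compound 2 and compound 3, both given only as limits: the limit of > 100000 nM in this assay, at which 3 of the 3 values shown sit.

The compounds shown leave open how the change from 4-fluorophenyl to phenyl acts in this assay, and whether any compound on the shared core gives a measurable value there.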